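This account rests on a few compounds, and the source may have more. Where it says the series, first, only, none or still open, it means among the compounds named here.

In a functional assay on A549 cells (Homo sapiens) for antiproliferative activity, read by MTT assay, with a stated time of 48 h (a lower number here means a stronger inhibitor of growth, a higher number a weaker inhibitor of growth), compound 2 `COC(=O)N1N=C(c2ccc(OC)cc2)CC1c1cc(OC)c(OC)c(OC)c1` gives 3400 nM and compound 1 `COC(=O)N1N=C(c2ccccc2)CC1c1cc(OC)c(OC)c(OC)c1` gives 2880 nM, so these two values lie within the scatter of each other. Compound 3 `CCCOC(=O)N1N=C(c2ccc(OC)cc2)CC1c1cc(OC)c(OC)c(OC)c1` is reported only as a limit, > 10000 nM. Compound 4 `CCOc1cccc(C2=NN(C(=O)OC)C(c3cc(OC)c(OC)c(OC)c3)C2)c1` is not yet measured; it carries 3-ethoxyphenyl in place of 4-methoxyphenyl on a carbon with a double bond to nitrogen. The closest evidence is a methoxy in place of hydrogen on an aromatic carbon, a 1.2-fold higher number from compound 1 to compound 2 (0.07 log units; within the scatter), which stayed within the scatter. The larger step, an at least 2.9-fold higher number from compound 2 to compound 3 (0.46 log units; beyond the scatter), came from a change at the ester, not on this aromatic ring. A step within the scatter is therefore expected, a 1.0-fold higher number from compound 2 to compound 4 (0.01 log units; within the scatter). For compound 4 the estimated value is 3500 nM, with an expected range of 1500 nM to 8000 nM.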

Compound 4, concentration for 50% growth inhibition: 5290 nM
Beside the measured number, compound 4's estimate is 1.5-fold (0.18 log units) below it; the measured number falls inside the stated range.
By their numbers in this assay, from the lowest: compounds 1, 2 and 4 (each within the scatter of the next). At a limit, above all of these: compound 3.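

In this assay, 3-ethoxyphenyl in place of 4-methoxyphenyl gives a 1.6-fold higher number from compound 2 to compound 4 (0.19 log units; within the scatter), and an added ethoxy group on the aromatic ring gives a 1.8-fold higher number from compound 1 to compound 4 (0.26 log units; within the scatter). Both steps stay within the scatter, so this aromatic ring, on the carbon with a double bond to nitrogen, now shows a change of group and of its place on the ring with no clear effect on the number. No measurement shown gives a reason for these steps. From the compounds shown here alone, what an amine, a carboxylic acid or a longer chain on this ring would do remains open. So does whether 3-methoxyphenyl or 4-ethoxyphenyl would read any differently.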